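Three Quinoline Ureas, One Unmeasured Tert-Butyl Analogue

The source may hold more compounds than are shown below. What is called first, only, known or untested is meant among the compounds shown, and "the series" means these compounds.

Measured so far:
- Compound 1, `Cc1cc(NC(=O)Nc2ccccc2F)c2ccccc2n1`: > 25000 nM
- Compound 2, `COC(=O)c1cccc(NC(=O)Nc2cc(C)nc3ccccc23)c1`: 26000 nM
- Compound 3, `COc1ccc(NC(=O)Nc2cc(C)nc3ccccc23)cc1OC`: > 25000 nM

All three share a urea link between a methyl-bearing quinoline core and a second aromatic ring. Among the compounds with values here, in an ADME assay on Raji cells (Homo sapiens) for cytotoxicity, with a stated time of 72 h (on this read-out higher numbers stand for an effect only at larger amounts of compound and lower numbers for an effect already at smaller amounts), compound 2 gives 26000 nM, the only actual number among the three. For compound 1 the result > 25000 nM is a limit of the assay, not a number. For compound 3 the result > 25000 nM is likewise a limit. Compound 2 therefore stands essentially at the edge where the other two fall off the scale, a position described by the limit of > 25000 nM in this assay, at which 2 of the 3 values shown sit; no ranking among the three can be drawn from this.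

Compound 4, `Cc1cc(NC(=O)Nc2cccc(C(C)(C)C)c2)c2ccccc2n1`, is the next compound to be tested. It differs from compound 2 in one place: tert-butyl in place of methoxycarbonyl on an aromatic carbon. The tert-butyl group carries no hydrogen-bond acceptors, where the methoxycarbonyl carried two.

Within the data shown here, with no measured step between related compounds to lean on, the expectation in this assay is a step of no size beyond the scatter, in neither direction, because compound 2 itself sits at 26000 nM. Compound 4 is estimated at 28000 nM, with a range from 10000 nM to 80000 nM. That estimate means a step from compound 2 to compound 4 of a 1.1-fold higher number from compound 2 to compound 4 (0.03 log units; within the scatter), and it is quite likely that only a limit, not a number, will be reported.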

Compound 4, half-maximal effective concentration: > 25000 nM
Compound 4 was reported as a limit; the forecaster's own chance of this, stated with the estimate: 65%; the middle value does not contradict the limit.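

In this assay compound 4 gives > 25000 nM, which is a limit of the assay and not a number. Within the data shown here, no step from compound 2 to compound 4 can therefore be read, and the values now gather at one edge: the limit of > 25000 nM in this assay, at which 3 of the 4 values shown sit. The compounds shown leave open whether changing the group on the second aromatic ring alters this read-out at all.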